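This account rests on a few compounds, and the source may have more. Where it says the series, first, only, none or still open, it means among the compounds named here.

Compound 3 `Cc1nc(C#Cc2ccc(C(=O)N[C@H](C)C(C)(C)O)nc2)cs1` is one of three compounds sharing a core that differ only in the group on a triple-bonded carbon. In a functional assay on HEK293 cells for positive allosteric modulation of metabotropic glutamate receptor 5 (Rattus norvegicus), read by fluorescence and calcium flux (on this read-out higher numbers stand for larger maximal responses and lower numbers for smaller maximal responses), compound 3 gives 66.6%, the uppermost of the three numbers, yet the gaps to its neighbours are small: the step of a number 5.4 percentage points higher from compound 1 to compound 3 (within the scatter) and the step of a number 6.7 percentage points higher from compound 2 to compound 3 (within the scatter) both lie within the scatter, so the three compounds stand essentially level. Compound 1 `C[C@@H](NC(=O)c1ccc(C#Cc2ccc(F)cc2F)cn1)C(C)(C)O` gives 61.2% in this assay, and compound 2 `Cc1ccccc1C#Cc1ccc(C(=O)N[C@H](C)C(C)(C)O)nc1` gives 59.9%, with the step of a number 1.3 percentage points lower from compound 1 to compound 2 (within the scatter) likewise within the scatter.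

Compound 4 `C[C@@H](NC(=O)c1ccc(C#CC2CCCC2)cn1)C(C)(C)O` is the next member, and it differs from compound 3 as follows: cyclopentyl in place of 2-methyl-1,3-thiazol-4-yl on a triple-bonded carbon. All three measured steps bear on this change, since each swaps the group on the same triple-bonded carbon, and none of them moves the maximal response beyond the scatter. For the measured compounds named here, those exchanges, however, all kept an aromatic ring in that position, whereas cyclopentyl is non-aromatic; no measured step covers such an exchange, so the estimate is less certain. A step of a number 4.6 percentage points lower from compound 3 to compound 4 (within the scatter) is expected, that is, none beyond the scatter. Compound 4 is therefore estimated to give 62% in this assay, within a range from 45% to 80%.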

Compound 4, largest response reached (reported as efficacy), in percent of the reference or control that the assay uses: 63.7%
Estimate against measurement, compound 4: 1.7 percentage points below; the range from low to high includes it.
By their numbers in this assay, from the lowest: compounds 2, 1, 4 and 3 (each within the scatter of the next).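

In this assay, for the compounds shown here, the earlier steps had exchanged only aromatic groups on the triple-bonded carbon, and compound 4 now brings a non-aromatic ring of carbon only to that place, with all three new steps staying within the scatter (a number 2.9 percentage points lower from compound 3 to compound 4 (within the scatter); a number 3.8 percentage points higher from compound 2 to compound 4 (within the scatter); a number 2.5 percentage points higher from compound 1 to compound 4 (within the scatter)). Among these four compounds, then, neither an aromatic ring nor the nitrogen and sulfur of the 2-methyl-1,3-thiazol-4-yl group is needed for the maximal response to stay level, so this position has so far tolerated every exchange shown, whether the ring is aromatic or not. Nothing measured here explains why the maximal response stays level across this change.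

The compounds shown leave open whether this tolerance extends beyond ring groups, for instance to an open chain such as n-butyl, to an amine such as dimethylaminomethyl, or to a carboxylic acid on the same triple-bonded carbon. They also leave open whether a smaller ring such as cyclopropyl or a larger one such as cyclohexyl would hold the maximal response at the same level as cyclopentyl.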